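Replacing the carbamoyl oxazole of compound 3 with a pyrazole

This account rests on a few compounds, and the source may have more. Where it says the series, first, only, none or still open, it means among the compounds named here.

Measured in a functional assay on A2780 cells (Homo sapiens) for inhibition; on this read-out higher numbers stand for weaker inhibition and lower numbers for stronger inhibition:
Compound 1 (`CCNC(=O)c1noc(-c2cc(C(C)C)c(O)cc2O)c1-c1cc(CN)no1`): "not determined" (no result reported)
Compound 2 (`CCNC(=O)c1noc(-c2cc(C(C)C)c(O)cc2O)c1-c1cc(C(=O)OCC)no1`): 9000 nM
Compound 3 (`CCNC(=O)c1noc(-c2cc(C(C)C)c(O)cc2O)c1-c1cc(C(N)=O)no1`): 15 nM

Compound 3 holds the lower of the two numbers available, 15 nM, while compound 2 is far higher and compound 1 has no number. The next compound, compound 4 (`CCNC(=O)c1noc(-c2cc(C(C)C)c(O)cc2O)c1-c1ccn(C(C)C)n1`), carries 1-isopropyl-1H-pyrazol-3-yl in place of 3-carbamoyl-1,2-oxazol-5-yl on an aromatic carbon.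

Among the measured compounds shown here, only one measured step bears on this change, and only indirectly. It is a 600-fold lower number from compound 2 to compound 3 (2.78 log units; beyond the scatter), with amino in place of ethoxy on a carbonyl carbon. That large step shows how far the number can move with a change within this group alone. For the measured compounds named here, compound 4 loses the whole group, but no measured compound shows a pyrazole, so the expectation is loose. The step expected here is a 10-fold higher number from compound 3 to compound 4 (1.00 log units; beyond the scatter), a moderate move toward weaker inhibition, smaller than the measured one. For compound 4 the estimated value is 150 nM, within an expected range of 20 nM to 1500 nM.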

Compound 4, half-maximal inhibitory concentration: 45 nM
The estimate for compound 4 lay 3.3-fold (0.52 log units) above the measured number; the range from low to high includes it.
By their numbers in this assay, from the lowest: compound 3; then compound 4; then compound 2.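

In this assay, the change gives a 3.0-fold higher number from compound 3 to compound 4 (0.48 log units; beyond the scatter) and so shows that a low number at this position does not depend on 3-carbamoyl-1,2-oxazol-5-yl, although the step is beyond the scatter. Its entering group, 1-isopropyl-1H-pyrazol-3-yl, has 0 hydrogen-bond donors, so the donor of the leaving group is not needed for a number in this low range. Against the ethyl ester, the same pyrazole gives a 200-fold lower number from compound 2 to compound 4 (2.30 log units; beyond the scatter) and the data shown offer no explanation for the size of either step.

The compounds shown leave open what the isopropyl group contributes, as none carries a methyl group or a longer chain on the pyrazole nitrogen. They also leave open how a carboxylic acid on the 1,2-oxazole would compare with the primary amide of compound 3 and the ethyl ester of compound 2.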